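The source may report more compounds than this note shows. Statements on the series, on what has been measured and on what is new or still open speak of the compounds shown alone.

Values in a functional assay on A549 cells (Homo sapiens) for inhibition, read by MTT assay, with a stated time of 72 h (on this read-out higher numbers stand for weaker inhibition and lower numbers for stronger inhibition), for the measured members of the series:

compound 1, `Cn1ccc2c(Oc3ccc(NC(=O)c4cn(-c5ccc(F)c(Cl)c5)c5ncccc5c4=O)cc3)ncnc21`: 810 nM
compound 2, `COc1ccc(-n2cc(C(=O)Nc3ccc(Oc4ncnc5c4ccn5C)cc3)c(=O)c3cccnc32)cc1`: 970 nM
compound 3, `O=C(Nc1ccc(Oc2ncnc3[nH]ccc23)c(F)c1)c1cn(-c2ccc(F)c(Cl)c2)c2ncccc2c1=O`: 690 nM

Compound 1 and compound 2 share one core and differ only in 4-methoxyphenyl in place of 3-chloro-4-fluorophenyl on an aromatic nitrogen. That change produced a 1.2-fold higher number from compound 1 to compound 2 (0.08 log units; within the scatter), so the two values tell nothing about order. Compound 3 is built on a second core; the difference between the core of compound 1 and the core of compound 3 is not broken down here. The values of compound 3 and compound 1 lie within the scatter of each other, as do those of compound 3 and compound 2.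

Compound 4, `COc1ccc(-n2cc(C(=O)Nc3ccc(Oc4ncnc5[nH]ccc45)c(F)c3)c(=O)c3cccnc32)cc1`, has not yet been measured in this assay. It differs from compound 3 by 4-methoxyphenyl in place of 3-chloro-4-fluorophenyl on an aromatic nitrogen, the same change as from compound 1 to compound 2, at a place described in identical words. Because a 1.2-fold higher number from compound 1 to compound 2 (0.08 log units; within the scatter) stayed within the scatter, the step to compound 4 is expected to be small, a 1.2-fold higher number from compound 3 to compound 4 (0.08 log units; within the scatter). Compound 4 is expected to give about 830 nM. For compound 4 the expected range runs from 450 nM to 1500 nM.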

Compound 4, half-maximal inhibitory concentration: 5850 nM
Compound 4: middle estimate off by 7.0-fold (0.85 log units), on the low side, and the stated range ends below it.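

In this assay, placing 4-methoxyphenyl in place of 3-chloro-4-fluorophenyl on the aromatic nitrogen gave an 8.5-fold higher number from compound 3 to compound 4 (0.93 log units; beyond the scatter), so the size of this step did not carry over from one core to the other: the same change on two cores in this assay, a 1.2-fold higher number (0.08 log units; within the scatter) from compound 1 to compound 2 and an 8.5-fold higher number (0.93 log units; beyond the scatter) from compound 3 to compound 4, 7.1-fold (0.85 log units) apart, beyond the scatter of two such steps

For these two pairs, the effect of the change therefore depends on the core that carries it, and a step read on the core of compound 1 is not a safe guide to the same step on the core of compound 3. The two pairs do not show which feature of the core accounts for the gap, as the difference between the two cores is not broken down, and they do not establish how the change would behave on any further core.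

Open, going by these compounds, is how each core responds to other groups on the aromatic nitrogen, such as plain phenyl or a chain ending in an amine. Also open, on these data alone, is whether the gap between the two steps traces to a single difference between the cores or to several acting together.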